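Swapping a Cyanophenyl for a Trimethoxyphenyl: Expected Cytotoxicity

A few compounds are considered here, and "the series" means these few. Any claim that something is new, unique, unknown or untested is made for them only; others in the source may bear on it.

Compound 1 `N#Cc1ccc(/C=C2\CN(S(=O)(=O)c3ccc(F)cc3)C/C(=C\c3ccc(C#N)cc3)C2=O)cc1` carries two 4-cyanophenyl groups on its core. In an ADME assay on L02 cells (Homo sapiens) for cytotoxicity, read by MTT assay, with a stated time of 24 h (on this read-out higher numbers stand for weaker inhibition and lower numbers for stronger inhibition), compound 1 gives 18900 nM. Compound 2 `COc1cc(/C=C2\CN(S(=O)(=O)c3ccc(F)cc3)C/C(=C\c3ccc(C#N)cc3)C2=O)cc(OC)c1OC` differs from it in one place: 3,4,5-trimethoxyphenyl in place of 4-cyanophenyl on a double-bonded chain carbon bound to a double-bonded ring carbon. This change gave a 1.5-fold lower number from compound 1 to compound 2 (0.17 log units; within the scatter), so in this assay compound 2 gives 12900 nM.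

Compound 3 `CC(=O)Nc1ccc(S(=O)(=O)N2C/C(=C\c3ccc(C#N)cc3)C(=O)/C(=C/c3ccccc3F)C2)cc1` is built on a different core; the difference between the core of compound 1 and the core of compound 3 is not broken down here. In this assay compound 3 gives 14400 nM, a value that lies within the scatter of both compound 1 and compound 2.

Compound 4 `COc1cc(/C=C2\CN(S(=O)(=O)c3ccc(NC(C)=O)cc3)C/C(=C\c3ccccc3F)C2=O)cc(OC)c1OC` has not yet been measured. It is related to compound 3 by the same kind of change that relates compound 2 to compound 1: 3,4,5-trimethoxyphenyl in place of 4-cyanophenyl on a double-bonded chain carbon bound to a double-bonded ring carbon. The place of the change is described in the same words in both pairs. Because the earlier change gave a 1.5-fold lower number from compound 1 to compound 2 (0.17 log units; within the scatter), a step of similar size is expected here, a 1.4-fold lower number from compound 3 to compound 4 (0.16 log units; within the scatter). Compound 4 is therefore estimated at 10000 nM, expected to fall between 5000 nM and 25000 nM.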

Compound 4, half-maximal inhibitory concentration: 14000 nM
Compound 4: the middle estimate sits 1.4-fold (0.15 log units) below what was measured; measured number inside the range.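

In this assay, putting 3,4,5-trimethoxyphenyl in place of 4-cyanophenyl on the core of compound 3 gave a 1.0-fold lower number from compound 3 to compound 4 (0.01 log units; within the scatter). Set beside the earlier step, this result gives no sign that the change behaves differently on the two cores: the same change on two cores in this assay, a 1.5-fold lower number (0.17 log units; within the scatter) from compound 1 to compound 2 and a 1.0-fold lower number (0.01 log units; within the scatter) from compound 3 to compound 4, 1.4-fold (0.15 log units) apart, within the scatter of two such steps. This agreement is a weak finding, however: each step lies within the scatter, so the two numbers in each pair cannot be told apart, and the data show neither that the change has a real effect on cytotoxicity in these cells nor that it would act the same way on a further core.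

The compounds shown leave open whether a different kind of group on that double-bonded chain carbon, such as an amine-bearing chain or a carboxylic acid, would shift the number beyond the scatter. They also leave open whether the agreement seen here would hold on a third core.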